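A few compounds are considered here, and "the series" means these few. Any claim that something is new, unique, unknown or untested is made for them only; others in the source may bear on it.

Measured so far, all in an assay on HEK293 cells for inhibition of Fatty-acid amide hydrolase 1 (Homo sapiens), read by fluorescence; a higher number here means a weaker inhibitor, a lower number a stronger inhibitor:
compound 1 `Cn1ccc2cc(-c3ccc4oc(Nc5ccc(F)cc5)nc4c3)ccc21` gives 99 nM;
compound 2 `Cn1ccc2cc(-c3ccc4oc(Nc5cccnc5)nc4c3)ccc21` gives 226 nM;
compound 3 `C[C@@H]1CN(c2nc3cc(-c4ccc5c(ccn5C)c4)ccc3o2)C[C@H](C)O1` gives 168 nM.

Compound 3 sits second highest of the three numbers. Its nearest neighbour is compound 2, and the gap between them is a 1.3-fold lower number from compound 2 to compound 3 (0.13 log units; within the scatter), within the scatter. The other gap, a 1.7-fold higher number from compound 1 to compound 3 (0.23 log units; within the scatter), is also within the scatter. Among the compounds with values here, only the step between compounds 1 and 2, a 2.3-fold higher number from compound 1 to compound 2 (0.36 log units; beyond the scatter), reaches beyond the scatter, and that step concerns a change on the nitrogen rather than on the ring carbon.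

Compound 4 `Cn1ccc2cc(-c3ccc4oc(N5Cc6cccnc6C5)nc4c3)ccc21` has not been measured. It differs from compound 3 by a group of 9 heavy atoms (7 carbon, 2 nitrogen; one five-membered non-aromatic ring with 1 hetero atom, one six-membered aromatic ring with 1 hetero atom) in place of a group of 8 heavy atoms (6 carbon, 1 nitrogen, 1 oxygen; one six-membered non-aromatic ring with 2 hetero atoms), on an aromatic carbon, at the place on an aromatic carbon of a five-membered aromatic ring with 1 nitrogen and 1 oxygen, part of a fused or bridged system of two rings, next to the ring nitrogen and next to the ring oxygen. Within the data shown here, the steps that bear on it are those to compound 3 from compound 1 and from compound 2, both within the scatter: two quite different groups at this carbon gave numbers close to each other. Compound 4 keeps a nitrogen-linked ring with the same count of acceptors and donors, so no step beyond the scatter is expected in this assay for compound 4, and the expected step from compound 3 is a 1.0-fold higher number from compound 3 to compound 4 (0.01 log units; within the scatter). The estimated value for compound 4 is 170 nM, with a range from 70 nM to 420 nM.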

Compound 4, half-maximal inhibitory concentration: 211 nM
Beside the measured number, compound 4's estimate is 1.2-fold (0.09 log units) below it; the measured number falls inside the stated range.
By their numbers in this assay, from the lowest: compounds 1, 3, 4 and 2 (each within the scatter of the next, the first and the last beyond it).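

In this assay, the aromatic carbon of the five-membered aromatic ring with 1 nitrogen and 1 oxygen now carries a third type of group, one of 9 heavy atoms with a five-membered non-aromatic ring and a six-membered aromatic ring, and this cannot be told apart from 2,6-dimethylmorpholin-4-yl (a 1.3-fold higher number from compound 3 to compound 4 (0.10 log units; within the scatter)) or from (pyridin-3-yl)amino (a 1.1-fold lower number from compound 2 to compound 4 (0.03 log units; within the scatter)). Against (4-fluorophenyl)amino a modest gap does appear (a 2.1-fold higher number from compound 1 to compound 4 (0.33 log units; beyond the scatter)), so compound 1 now has steps beyond the scatter to two of the other compounds, while compound 3 still goes against any clean separation, its step from compound 1 being within the scatter. No measurement is at hand that speaks to why these different groups give such close numbers.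

On these data alone, whether the gap around compound 1 belongs to the fluorine or to the whole aryl amino group stays open, since plain phenylamino, or 4-chlorophenylamino, would be needed to separate the two. Also open, as far as these compounds go, is how far this position tolerates groups of another kind, such as a small dimethylamino group, a longer alkylamino chain or a carboxylic acid on the ring.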